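Trifluoromethyl for methyl on the aryl ring of compound 1

This account rests on a few compounds, and the source may have more. Where it says the series, first, only, none or still open, it means among the compounds named here.

Going by the values given here, compound 1 `Cc1cccc(N2CCN(C(=O)C(C)N3C(=O)CC(C)C3=O)CC2)c1` is the member of the series that carries the only number in a functional assay on the whole organism (strain Swiss) with Mus musculus as the target, in the maximal electroshock model, with a stated time of 0.25 h; a higher number here means that more compound is needed for the effect, a lower number that less compound is needed: compound 1 gives 122 mg/kg. Compound 2 `CC(C(=O)N1CCN(c2ccccc2)CC1)N1C(=O)CC(C)(C)C1=O` in this assay gives > 130 mg/kg, which is a limit of the assay rather than a number. Among the compounds with values here, the one further value shown therefore sits at the limit of > 130 mg/kg in this assay, at which 1 of the 2 values shown sits. Compound 3 `CC1CC(=O)N(C(C)C(=O)N2CCN(c3cccc(C(F)(F)F)c3)CC2)C1=O` differs from compound 1 by trifluoromethyl in place of methyl on an aromatic carbon. Within the data shown here, no measured pair in the set shares this change, so no step size is known for it from data. The expected step of a 1.1-fold lower number from compound 1 to compound 3 (0.04 log units; within the scatter) is taken to stay within the usual scatter of this assay, with no settled direction. Compound 3 is accordingly estimated at 110 mg/kg, with a range from 50 mg/kg to 250 mg/kg, and a real chance that this assay reports only a limit.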

Compound 3, dose for half-maximal effect: 81.7 mg/kg
Compound 3: the middle estimate sits 1.3-fold (0.13 log units) above what was measured, within the range that was stated.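

In this assay, going by these compounds alone, trifluoromethyl in place of methyl on the aromatic carbon gives a 1.5-fold lower number from compound 1 to compound 3 (0.17 log units; within the scatter), which is the first measured size for this change, and that size lies within the scatter. The position therefore takes the larger group, and compound 3 still returns a number rather than a limit, with no separation from compound 1 that can be read as a real change. Nothing at hand gives a measured property that would account for this step.

Within the data shown here, compound 2 has a limit and not a number, and it differs from the others in more than one place, so no step to it can be read. On these data alone, whether this place also accepts a chlorine, a methoxy or a nitrile remains open, as does the effect of moving trifluoromethyl elsewhere on the ring.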